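A Chloro Group on the Benzyl Ether of Compound 1

The compounds below may be only part of what the source reports. "The series", "measured", "known", "first", "only" and "open" are said of these compounds alone.

Compound 1 `Cc1cc(C(=O)O)nn1Cc1cc(Br)ccc1OCc1ccccc1` gives 15.1 nM in a functional assay on CHO-K1 cells for antagonist activity at prostaglandin E2 receptor EP1 subtype (Homo sapiens), read by FLIPR (on this read-out higher numbers stand for weaker inhibition and lower numbers for stronger inhibition), the lowest of the two numbers measured. Compound 2 `CCCCc1cc(C(=O)O)nn1Cc1cc(Br)ccc1OCc1ccccc1` gives 977 nM in this assay, a step of a 65-fold higher number from compound 1 to compound 2 (1.81 log units; beyond the scatter). Compound 3 `Cc1cc(C(=O)O)nn1Cc1cc(Br)ccc1OCc1ccc(Cl)cc1` differs from compound 1 by chloro in place of hydrogen on an aromatic carbon. Among the compounds with values here, the one measured step alters the saturated chain carbon on the shared core, not the benzyl group, so no measured step bears directly on this change. With nothing pointing either way, a step within the scatter is expected, a 1.0-fold lower number from compound 1 to compound 3 (0.00 log units; within the scatter). Compound 3 is therefore estimated at 15 nM, within a range from 5 nM to 45 nM.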

Compound 3, inhibition constant: 8.71 nM
Compound 3: the middle estimate sits 1.7-fold (0.24 log units) above what was measured; the measured number falls inside the stated range.
By their numbers in this assay, from the lowest: compounds 3 and 1 (each within the scatter of the next); then compound 2.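

Chloro in place of hydrogen on the benzyl ring gives a 1.7-fold lower number from compound 1 to compound 3 (0.24 log units; within the scatter) in this assay and so leaves the number in place, which shows that this ring carbon can carry a chlorine without a measurable loss. The propyl change on the chain gave a 65-fold higher number from compound 1 to compound 2 (1.81 log units; beyond the scatter) and so moved the number far more than this one did. No measured evidence bears on this result.

A single chloro cannot show how fluoro, methoxy or a carboxylic acid on the same ring carbon would read.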